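Sigma-1 binding of chromone amines: an expected step

A few compounds are considered here, and "the series" means these few. Any claim that something is new, unique, unknown or untested is made for them only; others in the source may bear on it.

Measured compounds:
compound 1 `O=c1cc(-c2ccccc2)oc2cccc(OCCCCN3CCC(O)CC3)c12` 177 nM
compound 2 `O=c1cc(-c2ccccc2)oc2cccc(OCCCCCCCN3CCC(O)CC3)c12` 65 nM
compound 3 `CN(C)CCCCCCCCCOc1ccc2oc(-c3ccccc3)cc(=O)c2c1` 202 nM

In an assay on isolated protein (Cavia porcellus) with Sigma non-opioid intracellular receptor 1 (Homo sapiens) as the target, read by radioligand binding (a higher number here means a weaker inhibitor, a lower number a stronger inhibitor), compound 3 holds the highest number of the three; compound 1 sits within the scatter of it, while compound 2 sits clearly lower. Compound 4 `O=c1cc(-c2ccccc2)oc2ccc(OCCCCCCN3CCCC(O)C3)cc12` differs from compound 3 by 3-hydroxypiperidin-1-yl in place of 3-(dimethylamino)propyl on a saturated chain carbon, six bonds along the chain from an oxygen on an aromatic ring. Within the data shown here, no measured step covers this exact change. Among the measured compounds shown here, the one measured step, a 2.7-fold lower number from compound 1 to compound 2 (0.44 log units; beyond the scatter), shows only that lengthening the chain to the hydroxypiperidine gave a modest gain, and both hydroxypiperidine compounds stand at or below compound 3. A modest move toward lower numbers is therefore expected, a 2.0-fold lower number from compound 3 to compound 4 (0.31 log units; beyond the scatter), with the usual uncertainty. Compound 4 is estimated at 100 nM, within 40 nM to 300 nM.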

Compound 4, half-maximal inhibitory concentration: 77 nM
The estimate for compound 4 lay 1.3-fold (0.11 log units) above the measured number; the range from low to high includes it.
By their numbers in this assay, from the lowest: compounds 2 and 4 (each within the scatter of the next); then compounds 1 and 3 (each within the scatter of the next).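

In this assay, 3-hydroxypiperidin-1-yl in place of 3-(dimethylamino)propyl gave a 2.6-fold lower number from compound 3 to compound 4 (0.42 log units; beyond the scatter). Unlike the earlier step, which changed only the chain length, this one changes the amine end itself, on a saturated chain carbon, six bonds along the chain from an oxygen on an aromatic ring. Nothing available gives a reason for this step.

The compounds shown leave open whether the hydroxyl or the ring accounts for the step: a plain piperidine at this chain end would separate the two. Also open, from the compounds shown here alone, is how a 4-hydroxypiperidin-1-yl end would compare on this chain.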